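Aryl variation on the triazole nitrogen of the shared core

This account rests on a few compounds, and the source may have more. Where it says the series, first, only, none or still open, it means among the compounds named here.

Measured compounds:
Compound 1 `COc1ccc(-n2nncc2CN2C(=O)C3(C(C#N)=C(N)Oc4c3c3nc5ccccc5nc3c3ccccc43)c3ccccc32)cc1`: in a functional assay on A549 cells (Homo sapiens) for antiproliferative activity, read by MTT assay, with a stated time of 48 h (a higher number here means a weaker inhibitor, a lower number a stronger inhibitor), compound 1 gives > 50000 nM, which is a limit of the assay and not a number.
Compound 2 `N#CC1=C(N)Oc2c(c3nc4ccccc4nc3c3ccccc23)C12C(=O)N(Cc1cnnn1-c1ccc(N)cc1)c1ccccc12`: in this assay compound 2 gives > 50000 nM, likewise a limit of the assay.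
Compound 3 `N#CC1=C(N)Oc2c(c3nc4ccccc4nc3c3ccccc23)C12C(=O)N(Cc1cnnn1-c1cccc(S(N)(=O)=O)c1)c1ccccc12`: in this assay compound 3 gives 44200 nM.

Compound 3 thus holds the only number shown; the other two values are limits (the limit of > 50000 nM in this assay, at which 2 of the 3 values shown sit). The step of an at least 1.1-fold lower number from compound 1 to compound 3 (0.05 log units; that floor lies within the scatter) and the step of an at least 1.1-fold lower number from compound 2 to compound 3 (0.05 log units; that floor lies within the scatter) are each only a floor that lies within the scatter, and the step that the two limits leave unreadable from compound 1 to compound 2 cannot be read at all. No ordering of the three compounds follows from these values.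

Compound 4 `Cc1ccc(Cl)cc1-n1nncc1CN1C(=O)C2(C(C#N)=C(N)Oc3c2c2nc4ccccc4nc2c2ccccc32)c2ccccc21` carries the change (5-chloro-2-methylphenyl in place of 3-sulfamoylphenyl on an aromatic nitrogen). The measured steps that bear on it are the two aryl exchanges on the same nitrogen, from compound 1 and from compound 2 to compound 3, and both end at or close to the limit, so no direction beyond the scatter can be taken from them. Compound 4 is therefore expected to sit near the limit again, with the step of a 1.2-fold higher number from compound 3 to compound 4 (0.09 log units; within the scatter) expected to stay within the scatter. The estimate for compound 4 in this assay is 55000 nM, with a range from 20000 nM to 150000 nM, and a fair chance that only a limit is reported.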

Compound 4, half-maximal inhibitory concentration: > 50000 nM
Compound 4 ended at the assay's limit (the forecaster's own chance of this, stated with the estimate: 60%); the middle value is on the limit's open side.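

The exchange of 3-sulfamoylphenyl for 5-chloro-2-methylphenyl, a group with 0 hydrogen-bond donors and 0 hydrogen-bond acceptors, gives in this assay an at least 1.1-fold higher number from compound 3 to compound 4 (0.05 log units; that floor lies within the scatter), so removing the sulfamoyl group from this aromatic nitrogen shows no readable effect. The steps from compound 1 and from compound 2 to compound 4 cannot be read, as both ends of each are limits of the assay and not numbers. The new aryl group, with its chlorine and methyl substituents, therefore extends the range of groups tried at this position without giving an ordering, and most of the set now rests on the limit: the limit of > 50000 nM in this assay, at which 3 of the 4 values shown sit.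

From the compounds shown here alone, whether any group on this aromatic nitrogen can bring the number clearly clear of the limit remains open, for example a carboxylic acid on the aryl ring, or a longer alkyl chain or a saturated amine in place of the aryl ring. Also open, going by these compounds, is whether the four aryl groups differ at all in this assay, since a difference among them could lie hidden beyond the limit.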